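The source may hold more compounds than are shown below. What is called first, only, known or untested is meant among the compounds shown, and "the series" means these compounds.

Compound 1 `CCCCn1cc(CO[C@H]2CC(=O)[C@@H]3OC[C@H]2O3)nn1` gives, in a functional assay on MDA-MB-231 cells (Homo sapiens) for cytotoxicity, read by MTT assay, with a stated time of 48 h (on this read-out higher numbers stand for weaker inhibition and lower numbers for stronger inhibition), a value of 27900 nM, the lower of the two numbers recorded, though its gap to compound 2 is within the scatter. Compound 2 `COc1ccc(Cn2cc(CO[C@H]3CC(=O)[C@@H]4OC[C@H]3O4)nn2)cc1` gives 34800 nM in this assay, and the step of a 1.2-fold higher number from compound 1 to compound 2 (0.10 log units; within the scatter) is small. Compound 3 `O=C1CCCCC1n1cc(CO[C@H]2CC(=O)[C@@H]3OC[C@H]2O3)nn1` differs from compound 1 by 2-oxocyclohexyl in place of butyl on an aromatic nitrogen. For the measured compounds named here, the only measured step, which also exchanged the group on the aromatic nitrogen, stayed within the scatter, so the step to compound 3 is expected to be a 1.0-fold higher number from compound 1 to compound 3 (0.00 log units; within the scatter), with no shift beyond the scatter. Compound 3 is therefore estimated at 28000 nM, between 12000 nM and 65000 nM.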

Compound 3, half-maximal inhibitory concentration: 36000 nM
Compound 3: middle estimate off by 1.3-fold (0.11 log units), on the low side; the measured number falls inside the stated range.
By their numbers in this assay, from the lowest: compounds 1, 2 and 3 (each within the scatter of the next).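

In this assay, putting 2-oxocyclohexyl in place of butyl on the aromatic nitrogen gives a 1.3-fold higher number from compound 1 to compound 3 (0.11 log units; within the scatter) and so causes no shift beyond the scatter. For the compounds shown here, this extends what the earlier compounds showed: a group with a six-membered non-aromatic ring of carbon only and a carbonyl is also accommodated at this position without a shift beyond the scatter. Nothing available explains this result. Going by these compounds, whether an amine or a carboxylic acid on this nitrogen would move the number beyond the scatter remains open.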